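A Benzyl for Phenyl Step Along the Chain

A few compounds are considered here, and "the series" means these few. Any claim that something is new, unique, unknown or untested is made for them only; others in the source may bear on it.

Compound 1 `O=C(CCCCCCCCc1ccccc1)N1CCCCC1`: > 100000 nM
Compound 2 `O=C(CCCCCCc1ccccc1)N1CCCCC1`: > 100000 nM

Both entries come from a functional assay on PANC-1 cells (Homo sapiens) for cytotoxicity, read by WST assay, with a stated time of 24 h; a lower number here means a stronger inhibitor, a higher number a weaker inhibitor. Compound 2 stands only at a limit, > 100000 nM, so it offers no number to measure a change against. Compound 1 likewise gives only a limit, > 100000 nM. Within the data shown here, the series so far is summed up by the limit of > 100000 nM in this assay, at which 2 of the 2 values shown sit.

Compound 3 `O=C(CCCCCCCc1ccccc1)N1CCCCC1` departs from compound 2 by a single change, benzyl in place of phenyl on a saturated chain carbon, six bonds along the chain from a carbonyl carbon. Its chain is longer than that of compound 2 and shorter than that of compound 1.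

Among the measured compounds shown here, no step between two measured compounds is available to size this change. The expectation rests on compound 1 and compound 2 alone, through (the limit of > 100000 nM in this assay, at which 2 of the 2 values shown sit). In this assay, the estimated step of a number no higher from compound 2 to compound 3 (the limit leaves the size open) is expected to be none beyond the scatter, and a report of only a limit is the likely outcome. Compound 3 is estimated at 100000 nM, with an expected range of 50000 nM to 200000 nM.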

Compound 3, half-maximal inhibitory concentration: > 100000 nM
Compound 3: only a limit was reported; the forecaster's own chance of this, stated with the estimate: 90%; the middle value sits exactly at the limit.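

In this assay compound 3 gives > 100000 nM, which is a limit and not a number. Among these compounds, compound 1 and compound 2 likewise give only limits, and no step from either of them to compound 3 can be read. The compounds shown leave open what number each of the three would take and whether chain length changes it.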